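Adding a nitro group to a phenylsulfonyl compound

The source may report more compounds than this note shows. Statements on the series, on what has been measured and on what is new or still open speak of the compounds shown alone.

- Compound 1 `CCNc1nc(SCc2nc3ccccc3[nH]2)nc(-c2ccccc2)c1C#N`: 7.35 nM
- Compound 2 `N#Cc1c(Nc2ccccn2)nc(SCc2nc3ccccc3[nH]2)nc1-c1ccccc1`: 7.35 nM
- Compound 3 `N#Cc1c(-c2ccccc2)nc(SCc2nc3ccccc3[nH]2)nc1N1CCN(S(=O)(=O)c2ccccc2)CC1`: 3 nM

In a functional assay on KB cells (Homo sapiens) for cytotoxicity, read by MTT assay, with a stated time of 3 days (a higher number here means a weaker inhibitor, a lower number a stronger inhibitor), compound 3 gives 3 nM, the lowest of the three numbers, which makes it the strongest inhibitor so far. Its gap to each of the other two compounds lies beyond the scatter.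

The next compound is compound 4 `N#Cc1c(-c2ccccc2)nc(SCc2nc3ccccc3[nH]2)nc1N1CCN(S(=O)(=O)c2ccccc2[N+](=O)[O-])CC1`. It turns the phenylsulfonyl group of compound 3 into a (2-nitrophenyl)sulfonyl group, with nitro in place of hydrogen on an aromatic carbon, ortho to a large group: nitro in place of hydrogen on an aromatic carbon.

For the measured compounds named here, only one measured step compares compounds that differ in a single place: no change at the digits printed from compound 1 to compound 2 (within the scatter). That step swaps ethyl for pyridin-2-yl at another part of the molecule, so it bears on this change only weakly. Going by the values given here, no measured compound carries a nitro group. With so little to go on, no step beyond the scatter is expected in this assay, in either direction.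

The expected change is a 1.2-fold higher number from compound 3 to compound 4 (0.07 log units; within the scatter), and this is only an estimate.

For compound 4 the estimated value is 3.5 nM, with an expected range from 1.2 nM to 10 nM.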

Compound 4, half-maximal inhibitory concentration: 4.44 nM
The estimate for compound 4 lay 1.3-fold (0.10 log units) below the measured number, and the stated range covers the measured number.
By their numbers in this assay, from the lowest: compounds 3, 4, 1 and 2 (each within the scatter of the next, the first and the last beyond it).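

In this assay, nitro in place of hydrogen on an aromatic carbon of the phenylsulfonyl group, ortho to a large group, gives a 1.5-fold higher number from compound 3 to compound 4 (0.17 log units; within the scatter) and so no real change in potency. This is the only step shown on this ring, and it indicates that the ring can carry a nitro group, with its three heavy atoms and two hydrogen-bond acceptors, while the cell-killing potency stays in the same low range. No supporting measurement is available to explain this result.

The compounds shown leave open whether an amine, a carboxylic acid or a methoxy group on the same carbon would also leave the number within the scatter. They also leave open whether nitro would behave the same way on another carbon of this ring.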